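Bromo for methyl on the aryl ether of compound 2

The source may hold more compounds than are shown below. What is called first, only, known or untested is meant among the compounds shown, and "the series" means these compounds.

Among the compounds with values here, compound 2 `Cc1ccccc1OC1CCN(c2ccc(-n3ccnc3)nn2)CC1` stands at the higher of the two numbers so far: in an assay on microsomes from liver for inhibition of acyl-CoA desaturase 1 (Rattus norvegicus) (on this read-out higher numbers stand for weaker inhibition and lower numbers for stronger inhibition), compound 2 gives 39 nM, whereas compound 1 `O=C(NCCC1CC1)c1ccc(N2CCC(Oc3ccccc3C(F)(F)F)CC2)nn1` gives 14 nM, a gap beyond the usual scatter. Compound 3 `Brc1ccccc1OC1CCN(c2ccc(-n3ccnc3)nn2)CC1` differs from compound 2 by a single exchange: bromo in place of methyl on an aromatic carbon. Within the data shown here, no step between measured compounds covers this exchange, so its size cannot be read from the numbers at hand. The expected step of a 1.3-fold lower number from compound 2 to compound 3 (0.11 log units; within the scatter) is small, within the scatter, with no firm direction. Compound 3 is therefore estimated at 30 nM, with a range from 10 nM to 90 nM.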

Compound 3, half-maximal inhibitory concentration: 5 nM
For compound 3 the middle estimate is 6.0-fold (0.78 log units) above the measured one, outside the stated range (below it).
By their numbers in this assay, from the lowest: compound 3; then compound 1; then compound 2.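

In this assay the exchange of 2-methylphenoxy for 2-bromophenoxy gives a 7.8-fold lower number from compound 2 to compound 3 (0.89 log units; beyond the scatter) and so shows that this aromatic carbon responds to swapping one heavy atom for another, with no change in the count of hydrogen-bond donors or acceptors. The series is therefore sensitive at this position, at least for this pair. No measurement at hand accounts for the size of the step.

Going by these compounds, whether chloro, methoxy or nitrile on the same carbon would follow bromo remains open. So does whether the step carries over to other groups on the shared core.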